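The source may report more compounds than this note shows. Statements on the series, on what has been measured and on what is new or still open speak of the compounds shown alone.

Working notes on the benzofuran-free description of the series: compound 1 `CC(C)NC(=N)c1ccc(-c2cc3cc(C(=N)NC(C)C)ccc3o2)cc1` and compound 3 `COc1cc(C(=N)NC(C)C)cc2cc(-c3ccc(C(=N)NC(C)C)cc3)oc12` share one core and differ by methoxy in place of hydrogen on an aromatic carbon. In an ADME assay on L6 cells (Rattus norvegicus) for cytotoxicity (a higher number here means a weaker inhibitor, a lower number a stronger inhibitor), compound 1 gives > 198000 nM, which is a limit of the assay and not a number. Compound 3 likewise gives > 190000 nM in this assay, again a limit rather than a number. The step that the two limits leave unreadable from compound 1 to compound 3 therefore cannot be sized, because both ends sit at limits, the limit of > 198000 nM in this assay, at which 1 of the 3 values shown sits, and (the limit of > 190000 nM in this assay, at which 1 of the 3 values shown sits).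

Compound 2 `c1cc(C2=NCCN2)cc(-c2cc3cc(C4=NCCN4)ccc3o2)c1` carries a different core; how the two cores differ is not broken down here. In this assay, going by the values given here, compound 2 gives 33900 nM, the only actual number among the three values shown.

Compound 4 `COc1ccc(C2=NCCN2)cc1-c1cc2cc(C3=NCCN3)ccc2o1` is not yet measured and differs from compound 2 by methoxy in place of hydrogen on an aromatic carbon. The surroundings of the place are not the same as in compound 3: there the methoxy enters on a ring that is part of a fused or bridged system of two rings, ortho to a fused ring, meta to a fused ring and meta to a group of 6 heavy atoms, whereas in compound 4 it enters on a six-membered aromatic ring of carbon only, ortho to a large group and para to a group of 5 heavy atoms. It is the same kind of change, not the same change.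

The step from compound 2 to compound 4 in this assay is expected to be small, about a 1.0-fold higher number from compound 2 to compound 4 (0.00 log units; within the scatter), because compound 2 stands at 33900 nM and the measured precedent gives no readable size. Compound 4 is estimated to fall near 34000 nM, with a range from 15000 nM to 80000 nM.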

Compound 4, half-maximal inhibitory concentration: 30800 nM
Compound 4: the middle estimate sits 1.1-fold (0.04 log units) above what was measured; the measured number falls inside the stated range.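

In this assay, methoxy in place of hydrogen on an aromatic carbon of the core of compound 2, ortho to a large group and para to a group of 5 heavy atoms, gives a 1.1-fold lower number from compound 2 to compound 4 (0.04 log units; within the scatter), so this one readable step stays within the usual scatter. Compound 3, which carries the methoxy on the core of compound 1 in different surroundings, stands at a limit of the assay and not a number, and compound 1 is a limit as well, so that step cannot be read and offers no size to set against the new one: the limit of > 190000 nM in this assay, at which 1 of the 4 values shown sits. What stands is therefore a single readable step on one core at one place; it does not show that the change behaves alike on both cores, or that methoxy would give the same result elsewhere on either of them.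

Open, as far as these compounds go, is how the core of compound 2 answers at this same place to a group other than methoxy, such as a hydroxy group, an amine, a carboxylic acid or a longer chain like butoxy. Also open, from the compounds shown here alone, is how far the two cores lie apart in this assay, as the values shown for the core of compound 1 are limits only.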